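Replacing a tert-butoxycarbonyl Group with a Fluorinated Oxadiazole

A few compounds are considered here, and "the series" means these few. Any claim that something is new, unique, unknown or untested is made for them only; others in the source may bear on it.

Measured compounds:
- compound 1, `CCOC(=O)[C@@H]1CCC[C@H](S(=O)(=O)c2ccc(S(=O)(=O)N(CC)CC)cc2)C1`: 21500 nM
- compound 2, `CCN(CC)S(=O)(=O)c1ccc(S(=O)(=O)N2CCC[C@@H](C(=O)N3CCN(c4nc(C)no4)CC3)C2)cc1`: 250 nM
- compound 3, `CCN(CC)S(=O)(=O)c1ccc(S(=O)(=O)N2CCC[C@@H](C(=O)N3CCN(C(=O)OC(C)(C)C)CC3)C2)cc1`: 70 nM

All three were tested in a functional assay on MIA PaCa-2 cells (Homo sapiens) for inhibition, read by MTT assay, with a stated time of 7 days; a higher number here means a weaker inhibitor, a lower number a stronger inhibitor. Compound 1 gives the highest number of the three, and compound 3 the lowest; compound 2 sits between them, beyond the scatter from both. Compound 3 is therefore the strongest inhibitor among the measured compounds.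

Compound 4, `CCN(CC)S(=O)(=O)c1ccc(S(=O)(=O)N2CCC[C@@H](C(=O)N3CCN(c4nc(C(F)(F)F)no4)CC3)C2)cc1`, has not yet been measured. Its difference from compound 3 is 3-(trifluoromethyl)-1,2,4-oxadiazol-5-yl in place of tert-butoxycarbonyl on an amine nitrogen in a ring. Within the data shown here, the one measured step that bears on this change is the reverse of the move from compound 2 to compound 3, where a 3.6-fold lower number from compound 2 to compound 3 (0.55 log units; beyond the scatter). Going back from tert-butoxycarbonyl to an oxadiazole of the same kind would be expected to undo that gain, but the ring entering here carries trifluoromethyl rather than methyl, and no measured pair shows what that swap does.

On this basis compound 4 is expected to give a higher number than compound 3, with the step estimated as a 2.9-fold higher number from compound 3 to compound 4 (0.46 log units; beyond the scatter). The estimate for compound 4 in this assay is 200 nM, within a range from 60 nM to 650 nM.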

Compound 4, half-maximal inhibitory concentration: 600 nM
The estimate for compound 4 lay 3.0-fold (0.48 log units) below the measured number; measured number inside the range.
By their numbers in this assay, from the lowest: compound 3; then compound 2; then compound 4; then compound 1.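

In this assay, placing a 3-(trifluoromethyl)-1,2,4-oxadiazol-5-yl group on this amine nitrogen in a ring instead of tert-butoxycarbonyl gives an 8.6-fold higher number from compound 3 to compound 4 (0.93 log units; beyond the scatter), so this oxadiazole is a clearly weaker replacement in this series. The earlier compounds shown here showed what an oxadiazole carrying methyl does, but not whether the group on the oxadiazole matters; the step with trifluoromethyl in place of methyl on an aromatic carbon, a 2.4-fold higher number from compound 2 to compound 4 (0.38 log units; beyond the scatter), shows that it does, with methyl giving the stronger inhibitor of this pair. Neither oxadiazole reaches the number of compound 3, so tert-butoxycarbonyl remains the best of the three groups seen at this position, although only two oxadiazoles have been compared with it.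

No supporting measurement shown here explains these differences. Going by these compounds, it remains open how the oxadiazole would behave with hydrogen, ethyl or an amine in place of methyl or trifluoromethyl, and whether a simple acetyl or an ethyl carbamate on the same ring nitrogen would keep the number of compound 3.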